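Chloro for Methyl on the Quinoline Amide: What to Expect

The source may report more compounds than this note shows. Statements on the series, on what has been measured and on what is new or still open speak of the compounds shown alone.

Compound 1 `Cc1ccccc1-c1cc(C(=O)N2CCC3(CC2)CC(=O)c2nn(C(C)(C)C)cc2O3)c2ccccc2n1` in a functional assay on MDA-MB-231 cells (Homo sapiens) for inhibition, read by MTT assay, with a stated time of 72 h (on this read-out higher numbers stand for weaker inhibition and lower numbers for stronger inhibition), gives a value that is a limit of the assay, > 10000 nM. Compound 2 `CC(C)(C)n1cc2c(n1)C(=O)CC1(CCN(C(=O)c3cc(-c4ccccc4Cl)nc4ccccc34)CC1)O2` likewise gives only a limit, > 10000 nM. Compound 3 `Cc1cc(C(=O)N2CCC3(CC2)CC(=O)c2nn(C(C)(C)C)cc2O3)c2ccccc2n1` gives 4860 nM.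

Of the compounds shown here, three share one core and have been measured in this assay; only compound 3 yields a number, the other two sitting at the limit of > 10000 nM in this assay, at which 2 of the 3 values shown sit. Compound 3 differs from compound 1 by methyl in place of 2-methylphenyl on an aromatic carbon, and the step is an at least 2.0-fold lower number from compound 1 to compound 3 (0.31 log units; beyond the scatter). From compound 2 the step is an at least 2.0-fold lower number from compound 2 to compound 3 (0.31 log units; beyond the scatter).

The change of interest is chloro in place of methyl on an aromatic carbon. In this assay it gave a step that the two limits leave unreadable from compound 1 to compound 2. Compound 4 `CC(C)(C)n1cc2c(n1)C(=O)CC1(CCN(C(=O)c3cc(Cl)nc4ccccc34)CC1)O2` is made from compound 3 by chloro in place of methyl on an aromatic carbon. The place is not the same: in compound 1 the change sits on an aromatic carbon of a six-membered aromatic ring of carbon only, ortho to a large group, whereas in compound 3 it sits on an aromatic carbon of a six-membered aromatic ring with 1 nitrogen, part of a fused or bridged system of two rings, next to the ring nitrogen. It is therefore the same kind of change, not the same.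

The estimate means a step of a 1.1-fold higher number from compound 3 to compound 4 (0.05 log units; within the scatter), which is expected because compound 3 gives 4860 nM and the unreadable a step that the two limits leave unreadable from compound 1 to compound 2 gives no direction. Compound 4 is accordingly expected near 5500 nM, between 2000 nM and 15000 nM.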

Compound 4, half-maximal inhibitory concentration: 9220 nM
Estimate against measurement, compound 4: 1.7-fold (0.22 log units) below; measured number inside the range.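

In this assay chloro in place of methyl on the aromatic carbon next to the ring nitrogen gives a 1.9-fold higher number from compound 3 to compound 4 (0.28 log units; within the scatter) and so leaves no difference that can be told from repeated measurement at this place. Whether the change behaves alike in both places stays unshown, since the step between compound 1 and compound 2 joins two limits and cannot be read: the limit of > 10000 nM in this assay, at which 2 of the 4 values shown sit. The other two new steps, an at least 1.0-fold lower number from compound 2 to compound 4 (0.03 log units; that floor lies within the scatter) and an at least 1.0-fold lower number from compound 1 to compound 4 (0.03 log units; that floor lies within the scatter), do not set compound 4 apart from either compound, so this small set gives no rule for carrying the change from one place to another.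

The compounds shown carry only methyl, chloro, 2-methylphenyl and 2-chlorophenyl on this aromatic carbon, so what an amine, a carboxylic acid or a longer alkyl chain would give there remains open. Also open, on these data alone, is how far compound 1 and compound 2 truly stand from compound 4, and whether chloro and methyl would stay this close on a different core.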